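This account rests on a few compounds, and the source may have more. Where it says the series, first, only, none or still open, it means among the compounds named here.

The measured compounds:

Compound 1 `CCc1cccc(NC(=O)CN2CCC(c3cccc[n+]3[O-])CC2)c1` in a functional assay on HEK293 cells for agonist activity at D(4) dopamine receptor (Homo sapiens), read by FLIPR (on this read-out higher numbers stand for an effect only at larger amounts of compound and lower numbers for an effect already at smaller amounts), gives 95 nM.
Compound 2 `O=C(NCN1CCC(c2cccc[n+]2[O-])CC1)c1ccccc1` in this assay gives 532 nM.
Compound 3 `c1ccc(C2CCN(Cc3nc4ccccc4[nH]3)CC2)nc1` in this assay gives 12 nM.

Compound 2 carries the highest of the three numbers. Its nearest neighbour is compound 1, whose number is lower by a margin beyond the scatter, and compound 3 stands furthest away, with a number lower by a margin well beyond the scatter. No two of the three compounds differ in only one place, so nothing here shows the weight of a single change.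

Compound 4 `O=C(NCN1CCC(c2cccc[n+]2[O-])CC1)c1ccccn1` has not yet been measured. It differs from compound 2 in one place: pyridin-2-yl in place of phenyl on a carbonyl carbon. The amide-linked piperidine and the pyridine N-oxide of compound 2 remain unchanged. The shown compounds offer no step in which an aromatic carbon is swapped for an aromatic nitrogen in this position. With nothing to anchor a direction, the step from compound 2 to compound 4 is expected to be a 1.1-fold lower number from compound 2 to compound 4 (0.03 log units; within the scatter), that is, no change beyond the scatter. Compound 4 is accordingly expected to give about 500 nM in this assay, within a range of 150 nM to 1800 nM.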

Compound 4, half-maximal effective concentration: 3150 nM
Compound 4: middle estimate off by 6.3-fold (0.80 log units), on the low side; the whole stated range lies below it.
By their numbers in this assay, from the lowest: compound 3; then compound 1; then compound 2; then compound 4.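

In this assay, among the compounds shown here, the swap of phenyl for pyridin-2-yl on the carbonyl carbon gives a 5.9-fold higher number from compound 2 to compound 4 (0.77 log units; beyond the scatter) and so lies beyond the scatter, the first single change whose weight can be read. The entering and leaving rings have the same count of heavy atoms and differ by one ring nitrogen, counted as one hydrogen-bond acceptor, so this place in compound 2 responds to a change of that size, and in the direction of a higher number. Nothing given here accounts for the direction or size of this step.

The compounds shown leave open whether pyridin-3-yl or pyridin-4-yl on the same carbonyl carbon would shift the number as pyridin-2-yl does. They also leave open whether the same swap would carry the same weight on a core other than that of compound 2.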